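Coumarin sulfonamide series: trimming one pyrimidine methyl

The source may report more compounds than this note shows. Statements on the series, on what has been measured and on what is new or still open speak of the compounds shown alone.

Measured so far, in a functional assay on MCF7 cells (Homo sapiens) for cytotoxicity, read by CCK-8 assay, with a stated time of 48 h; on this read-out lower numbers stand for stronger inhibition and higher numbers for weaker inhibition:
compound 1, `Cc1ccnc(NS(=O)(=O)c2ccc(/N=C/c3c(Cl)c4ccccc4oc3=O)cc2)n1`, gives 31 nM
compound 2, `Cc1ccc2oc(=O)c(/C=N/c3ccc(S(N)(=O)=O)cc3)c(Cl)c2c1`, gives 270 nM
compound 3, `Cc1ccc2oc(=O)c(/C=N/c3ccc(S(=O)(=O)Nc4nc(C)cc(C)n4)cc3)c(Cl)c2c1`, gives 25 nM

Compound 3 holds the lowest number of the three, but compound 1 lies within the scatter of it; only compound 2 stands clearly apart. Compound 4, `Cc1ccc2oc(=O)c(/C=N/c3ccc(S(=O)(=O)Nc4nccc(C)n4)cc3)c(Cl)c2c1`, is not yet measured. Its difference from compound 3: hydrogen in place of methyl on an aromatic carbon. Among the compounds with values here, no measured step covers this change. Within the data shown here, the single one-point step, an 11-fold lower number from compound 2 to compound 3 (1.03 log units; beyond the scatter), concerns adding the whole ring to the sulfonamide nitrogen, not removing a methyl from it. Among the measured compounds shown here, compound 4 shares its 4-methylpyrimidin-2-yl group with compound 1, which on a different core gives 31 nM, while compound 3 gives 25 nM; that pair differs in two places, so it shows only that the two ring variants give numbers within the scatter of each other. The expected step of a 1.2-fold higher number from compound 3 to compound 4 (0.08 log units; within the scatter) is therefore none beyond the scatter. Compound 4 is estimated at 30 nM, with a range of 12 nM to 75 nM.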

Compound 4, half-maximal inhibitory concentration: 61 nM
Compound 4: middle estimate off by 2.0-fold (0.31 log units), on the low side; the range from low to high includes it.
By their numbers in this assay, from the lowest: compounds 3, 1 and 4 (each within the scatter of the next, the first and the last beyond it); then compound 2.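

In this assay the methyl opposite the ring nitrogen proves to be a position where a single carbon counts: taking it off gives a modest change beyond the scatter (a 2.4-fold higher number from compound 3 to compound 4 (0.39 log units; beyond the scatter)). The 4-methylpyrimidin-2-yl group still improves on the unsubstituted sulfonamide (a 4.4-fold lower number from compound 2 to compound 4 (0.65 log units; beyond the scatter)), so the ring keeps a modest step beyond the scatter with this methyl gone. By contrast, the methyl that separates the core of compound 1 from the core of compound 4 gives no change that can be read (a 2.0-fold higher number from compound 1 to compound 4 (0.29 log units; within the scatter)).

No measurement here explains the step at the ring methyl.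
Open, on these data alone, is how an ethyl, methoxy or amino group on that aromatic carbon would compare with methyl and hydrogen, and whether the methyl step carries over to the core of compound 1.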